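Swapping the Sulfonyl Aryl Group on a Shared Core

The compounds below may be only part of what the source reports. "The series", "measured", "known", "first", "only" and "open" are said of these compounds alone.

Compound 1 `Cn1nc(S(=O)(=O)c2ccccc2)c2cc(N3CCNCC3)ccc21` and compound 2 `CN1CCN(c2ccc3[nH]nc(S(=O)(=O)c4c(Cl)cccc4Cl)c3c2)CC1` share a core that carries a sulfonyl group. In a functional assay on HeLa cells for antagonist activity at 5-hydroxytryptamine receptor 6 (Homo sapiens) (on this read-out higher numbers stand for larger maximal responses and lower numbers for smaller maximal responses), compound 1 reaches 100%. In this assay compound 2 reaches 100%, level with compound 1 at the digits shown, a difference that lies within the usual scatter of such measurements. Compound 3 `CN1CCN(c2ccc3[nH]nc(S(=O)(=O)c4cccs4)c3c2)CC1` is built from compound 2 by a single change: thiophen-2-yl in place of 2,6-dichlorophenyl on a sulfonyl sulfur. Among the compounds with values here, no pair of measured compounds shows this change, so its effect on the maximal response can only be judged from the two measured compounds. Because compound 2 already gives 100%, a full response, the step in this assay is expected to be none beyond the scatter, with a small drop as the only likely alternative. The expected step is no change at the digits printed from compound 2 to compound 3 (within the scatter). For compound 3 the estimated value in this assay is 100%, with a range from 82% to 100%.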

Compound 3, largest response reached (reported as Imax), in percent of the reference or control that the assay uses: 96%
For compound 3 the middle estimate is 4 percentage points above the measured one, and the stated range covers the measured number.
By their numbers in this assay, from the lowest: compounds 3, 1 and 2 (each within the scatter of the next).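

On the sulfonyl sulfur, putting thiophen-2-yl in place of 2,6-dichlorophenyl gives, in this assay, a number 4 percentage points lower from compound 2 to compound 3 (within the scatter), so this swap leaves the maximal response level within the scatter. Within the data shown here, this is the first comparison here in which only this group differs, which compound 1 and compound 2 could not offer, as they differ in more than one place. It shows that this position accepts a five-membered aromatic ring with one hetero atom as well as a six-membered carbon ring bearing chlorine, with no loss of response beyond the scatter, though nothing available explains that result.

Still open, going by these compounds, is whether a non-aromatic group on the sulfonyl sulfur, such as a methyl group or a simple amine, would give the same response. Whether a larger aromatic group, such as naphthyl, would do so is equally unknown.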